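The compounds below may be only part of what the source reports. "The series", "measured", "known", "first", "only" and "open" are said of these compounds alone.

Measured compounds:
- compound 1 `CCc1nc(N)nc2c1c(-c1ccc3oc(N)nc3c1)nn2C(C)C` gives 62000 nM in a physicochemical assay for solubility, read by HPLC, in phosphate buffer, measured as kinetic solubility, with a stated time of 24 h, at 20 degrees C, at pH 7.4, tested at 100 uM; a lower number here means a less soluble compound, a higher number a more soluble compound
- compound 2 `CC(C)n1nc(-c2ccc3oc(N)nc3c2)c2c(Cl)nc(N)nc21` gives 2000 nM in this assay
- compound 3 `CC(C)n1nc(-c2ccc3oc(N)nc3c2)c2c(=O)[nH]c(N)nc21` gives 9200 nM in this assay

Compound 3 stands second highest of the three numbers in this assay; its nearest neighbour is compound 2, its furthest compound 1, both gaps beyond the scatter. Within the data shown here, the only step measured on the shared core is a 31-fold lower number from compound 1 to compound 2 (1.49 log units; beyond the scatter), a large shift from one change on an aromatic carbon.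

Compound 4 `Cc1nc2c(c(-c3ccc4oc(N)nc4c3)nn2C(C)C)c(=O)[nH]1` is not yet measured. It differs from compound 3 by methyl in place of amino on an aromatic carbon, on an aromatic carbon of a six-membered aromatic ring with two nitrogen, between two ring nitrogen atoms. Among the measured compounds shown here, no measured step exchanges amino for methyl, so the step from compound 1 to compound 2 does not transfer directly; it only shows that single changes on this core can move the number far. For the measured compounds named here, with no matching precedent, a moderate step is expected, a 1.8-fold lower number from compound 3 to compound 4 (0.26 log units; within the scatter), most likely toward a lower number. Compound 4 is therefore estimated at 5000 nM, within 1500 nM to 15000 nM.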

Compound 4, solubility: 3000 nM
Beside the measured number, compound 4's estimate is 1.7-fold (0.22 log units) above it; the measured number falls inside the stated range.
By their numbers in this assay, from the lowest: compounds 2 and 4 (each within the scatter of the next); then compound 3; then compound 1.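

Methyl in place of amino, on the aromatic carbon between two ring nitrogen atoms, gives a 3.1-fold lower number from compound 3 to compound 4 (0.49 log units; beyond the scatter) in this assay, the first reading of a change at this position. The earlier step, a 31-fold lower number from compound 1 to compound 2 (1.49 log units; beyond the scatter), lay at a different place on the shared core, so the new result shows that the number also responds to a single-atom exchange here, though this step is only modest. No available measurement explains the direction or size of this change.

Still open, going by these compounds, is how this assay reads with other groups at this position, such as hydrogen, methoxy, dimethylamino or a longer chain. Also open, on these data alone, is whether methyl in place of amino gives a similar step when ethyl or chloro occupies the other aromatic carbon.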